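Aryl ether for the amide chain at the acyl carbon

This account rests on a few compounds, and the source may have more. Where it says the series, first, only, none or still open, it means among the compounds named here.

Compound 3 `CC(C)C[C@H](N)c1cc(C(F)(F)F)ccc1N1CCN(C(=O)CCC(=O)N(C)C)CC1` stands at the limit of an assay on HEK293 cells for displacement of a labelled ligand from Melanocortin receptor 4 (Homo sapiens); a lower number here means a stronger inhibitor, a higher number a weaker inhibitor: compound 3 gives > 10000 nM, a limit of the assay rather than a number, (the limit of > 10000 nM in this assay, at which 1 of the 3 values shown sits). Compound 4 `Cc1ccc(OCC(=O)N2CCN(c3ccc(C(F)(F)F)cc3[C@@H](N)CC(C)C)CC2)cc1` differs from it by 4-methylphenoxy in place of (dimethylcarbamoyl)methyl on a saturated chain carbon bound to a carbonyl carbon. The step that bears on this change runs the opposite way, an at least 3.8-fold higher number from compound 2 to compound 3 (0.58 log units; beyond the scatter), where compound 2 `CC(C)C[C@H](N)c1cc(C(F)(F)F)ccc1N1CCN(C(=O)COc2cccc3ccccc23)CC1` gives 2600 nM. Compound 1 `Cc1ccc(CC(C)C(=O)N2CCN(c3ccc(C(F)(F)F)cc3[C@@H](N)CC(C)C)CC2)cc1C` gives 240 nM, and an 11-fold higher number from compound 1 to compound 2 (1.03 log units; beyond the scatter) together with an at least 41-fold higher number from compound 1 to compound 3 (1.61 log units; beyond the scatter) shows that both acyl variants lag it. With an aryl ether again on the saturated chain carbon bound to a carbonyl carbon, compound 4 is expected to move to a lower number, an at least 3.3-fold lower number from compound 3 to compound 4 (0.52 log units; beyond the scatter), the size uncertain since compound 3 is only a limit. Compound 4 is estimated at 3000 nM, between 800 nM and 12000 nM.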

Compound 4, inhibition constant: 4400 nM
Beside the measured number, compound 4's estimate is 1.5-fold (0.17 log units) below it; measured number inside the range.
By their numbers in this assay, from the lowest: compound 1; then compounds 2 and 4 (each within the scatter of the next). At a limit, above all of these: compound 3.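

In this assay compound 3 gives > 10000 nM, a limit of the assay and not a number, so the move to 4-methylphenoxy can be read only as a minimum: an at least 2.2-fold lower number from compound 3 to compound 4 (0.35 log units; beyond the scatter). The size of the aryl group on the ether oxygen makes no readable difference here, with a 1.7-fold higher number from compound 2 to compound 4 (0.23 log units; within the scatter). Neither aryl ether approaches the acyl group of compound 1, and the second confirms the gap: an 18-fold higher number from compound 1 to compound 4 (1.26 log units; beyond the scatter).

The compounds shown do not separate the contribution of the ether oxygen from that of the methyl groups on the acyl chain of compound 1. Also open, from the compounds shown here alone, is how an amine or a carboxylic acid on the saturated chain carbon bound to a carbonyl carbon would read.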